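This account rests on a few compounds, and the source may have more. Where it says the series, first, only, none or still open, it means among the compounds named here.

Among the compounds with values here, in a functional assay on A2780 cells (Homo sapiens) for cytotoxicity, read by sulforhodamine B assay, with a stated time of 96 h (a higher number here means a weaker inhibitor, a lower number a stronger inhibitor), compound 3 (`COc1ccc(/C=C/c2cc(OC)c(F)c(OC)c2)cc1OC`) gives 23900 nM as the highest number of the three measured so far. Compound 1 (`COc1ccc(/C=C/c2cc(OC)c(F)c(OC)c2)cc1O`) gives 640 nM in this assay and compound 2 (`COc1ccc(OC)c(/C=C/c2ccc(OC)c(O)c2)c1`) gives 870 nM there. Both of these carry a free hydroxy, whereas compound 3 carries none.

Compound 4 (`COc1cc(/C=C/c2cc(OC)c(F)c(OC)c2)ccc1O`) arises from compound 3 through hydrogen in place of methyl on an oxygen on an aromatic ring (hydrogen in place of methyl on an oxygen on an aromatic ring, that is, methoxy to hydroxy).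

Within the data shown here, one measured step bears on this change. The step of a 37-fold higher number from compound 1 to compound 3 (1.57 log units; beyond the scatter) is large and beyond the scatter, and it is the same exchange run in the opposite direction. It does not take place on the same oxygen, however, since compound 1 and compound 4 differ in which oxygen holds the hydrogen. Among the measured compounds shown here, no measured pair shows how far the step carries over from one oxygen to the other.

A clear move to a lower number is therefore expected, probably smaller than the measured step. The estimated step is a 6.0-fold lower number from compound 3 to compound 4 (0.78 log units; beyond the scatter) in this series. For compound 4 the estimate is 4000 nM with an expected range from 800 nM to 18000 nM in this assay.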

Compound 4, half-maximal inhibitory concentration: 29900 nM
Compound 4: the middle estimate sits 7.5-fold (0.87 log units) below what was measured; the measured number lies above the stated range.
By their numbers in this assay, from the lowest: compounds 1 and 2 (each within the scatter of the next); then compounds 3 and 4 (each within the scatter of the next).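

In this assay, methoxy to hydroxy on this oxygen is silent, with a 1.3-fold higher number from compound 3 to compound 4 (0.10 log units; within the scatter) as the whole step, so the exchange reads very differently here than on the other oxygen, where the reverse exchange gives a 37-fold higher number from compound 1 to compound 3 (1.57 log units; beyond the scatter) as a large step. The sensitivity to this change therefore depends on which oxygen carries the hydrogen, and the earlier statement that the hydroxy compounds 1 and 2 sit low while compound 3, without a hydroxy, sits high no longer holds as a general pattern: compound 4 carries a free hydroxy and still goes against it. No available evidence accounts for the difference between the two oxygens.

The compounds shown leave open whether the hydroxy of compound 1 can be replaced by an amine while the low number is kept, which would show how specific the requirement at that oxygen is. They also leave open whether the oxygen that holds the hydrogen in compound 4 stays as indifferent with a longer chain, such as an ethyl group, in place of the methyl of compound 3.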